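Trimming the nitrogen substituent on a trimethoxybenzyl purine analogue

This account rests on a few compounds, and the source may have more. Where it says the series, first, only, none or still open, it means among the compounds named here.

Compound 1 `CCC(CC)Cn1c(Cc2cc(OC)c(OC)c(OC)c2)nc2c(N)ncnc21`: 158000 nM
Compound 2 `CC#CCCn1c(Cc2cc(OC)c(OC)c(OC)c2)nc2c(N)nc(F)nc21`: 37200 nM
Compound 3 `CCCn1c(Cc2cc(OC)c(OC)c(OC)c2)nc2c(N)nc(F)nc21`: 25100 nM

In a functional assay on MCF7 cells (Homo sapiens) for antiproliferative activity (on this read-out lower numbers stand for stronger inhibition and higher numbers for weaker inhibition), compound 1 gives the highest of the three numbers, beyond the scatter from both compound 2 and compound 3. Compound 4 `CCn1c(Cc2cc(OC)c(OC)c(OC)c2)nc2c(N)ncnc21` differs from compound 1 by methyl in place of pentan-3-yl on a saturated chain carbon bound to an aromatic nitrogen. Going by the values given here, the only measured step of a similar kind, a 1.5-fold lower number from compound 2 to compound 3 (0.17 log units; within the scatter), also shortens the chain on that nitrogen and stays within the scatter. That step, however, is a smaller cut, and compounds 2 and 3 carry a fluorine that compound 1 and compound 4 lack, so the expectation rests on thin ground. Compound 4 is therefore expected to show a 1.6-fold lower number from compound 1 to compound 4 (0.20 log units; within the scatter), a modest drop in number at most. The estimate for compound 4 is 100000 nM, within 30000 nM to 300000 nM.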

Compound 4, half-maximal inhibitory concentration: 79400 nM
The estimate for compound 4 lay 1.3-fold (0.10 log units) above the measured number; the measured number falls inside the stated range.
By their numbers in this assay, from the lowest: compounds 3 and 2 (each within the scatter of the next); then compounds 4 and 1 (each within the scatter of the next).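

In this assay, methyl in place of pentan-3-yl on a saturated chain carbon bound to an aromatic nitrogen gives a 2.0-fold lower number from compound 1 to compound 4 (0.30 log units; within the scatter), which lies within the scatter. This extends the earlier reading to a much larger cut and to compounds without fluorine: even the change from 2-ethylbutyl to ethyl does not separate the two numbers. Nothing available gives a reason for this result. As far as these compounds go, what the fluorine of compound 2 and compound 3 contributes remains open, as does whether an amine or a carboxylic acid on this chain would shift the number beyond the scatter.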